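The source may report more compounds than this note shows. Statements on the series, on what has been measured and on what is new or still open speak of the compounds shown alone.

In an ADME assay on microsomes from liver (Homo sapiens) for metabolic stability, tested at 2.5 uM (a lower number here means slower removal, a higher number faster removal of the compound), three compounds have been measured so far:
compound 1 `COc1cccc(-c2c(S(=O)(=O)c3cccc(C#N)c3)cnc3cc(F)ccc23)c1` gives 1.83 mL/min;
compound 2 `COc1cccc(-c2c(S(=O)(=O)c3cc(Cl)cc(Cl)c3)cnc3cc(F)ccc23)c1` gives 1.51 mL/min;
compound 3 `N#Cc1cccc(S(=O)(=O)c2cnc3c(F)cccc3c2-c2ccc(Cl)cc2)c1` gives 0.08 mL/min.

Compound 2 differs from compound 1 in one place only: 3,5-dichlorophenyl in place of 3-cyanophenyl on a sulfonyl sulfur. That change made a 1.2-fold lower number from compound 1 to compound 2 (0.08 log units; within the scatter). Compound 3 stands apart from both with a far lower number in this assay; the difference between its core and the core of compound 1 is not broken down here.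

Compound 4 `O=S(=O)(c1cc(Cl)cc(Cl)c1)c1cnc2c(F)cccc2c1-c1ccc(Cl)cc1` has not yet been measured. It carries the same change relative to compound 3: 3,5-dichlorophenyl in place of 3-cyanophenyl on a sulfonyl sulfur. Given a 1.2-fold lower number from compound 1 to compound 2 (0.08 log units; within the scatter), the same change is expected to give a 1.1-fold lower number from compound 3 to compound 4 (0.06 log units; within the scatter). On that basis compound 4 is estimated at 0.07 mL/min, with a likely range from 0.03 mL/min to 0.18 mL/min.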

Compound 4, intrinsic clearance in a liver preparation (reported as CLH), per the amount of preparation that the assay uses: 0.78 mL/min
Compound 4: middle estimate off by 11-fold (1.05 log units), on the low side, outside the stated range (above it).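

In this assay, putting 3,5-dichlorophenyl in place of 3-cyanophenyl on a sulfonyl sulfur gave a 9.8-fold higher number from compound 3 to compound 4 (0.99 log units; beyond the scatter). The size of this step therefore did not carry over from one core to the other: the same change on two cores in this assay, a 1.2-fold lower number (0.08 log units; within the scatter) from compound 1 to compound 2 and a 9.8-fold higher number (0.99 log units; beyond the scatter) from compound 3 to compound 4, 12-fold (1.07 log units) apart, beyond the scatter of two such steps. This does not show which difference between the two cores matters, or how the change would behave on any further core.

The compounds shown leave open how a phenyl group carrying an amine or a carboxylic acid on the sulfonyl sulfur would behave on either core. They also leave open the size of the step on a core that shares only part of the difference between the core of compound 1 and the core of compound 3.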